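A few compounds are considered here, and "the series" means these few. Any claim that something is new, unique, unknown or untested is made for them only; others in the source may bear on it.

Compound 2 `COc1nc2c(c(=O)n(C)c(=O)n2C)n1CCCC(=O)Nc1ccc(C(C)C)cc1` carries the shared core with a methoxy group and an amide to a 4-isopropylphenyl ring. In an assay on isolated protein for inhibition of high affinity 3',5'-cyclic-AMP phosphodiesterase 7A (Homo sapiens), read by cAMP accumulation, with a stated time of 10 min (on this read-out lower numbers stand for stronger inhibition and higher numbers for weaker inhibition), compound 2 gives only a limit, > 200000 nM, and no number. Compound 1 `COc1nc2c(c(=O)n(C)c(=O)n2C)n1CCCC(=O)Nc1ccc(C(C)(C)C)cc1` differs by a methyl, and in this assay compound 1 gives 19800 nM. Compound 3 `COc1nc2c(c(=O)n(C)c(=O)n2C)n1CCCC(=O)NCc1ccccc1Cl` gives in this assay likewise a limit, > 200000 nM. The step from compound 1 to compound 2 is an at least 10-fold higher number from compound 1 to compound 2 (1.00 log units; beyond the scatter), and that from compound 1 to compound 3 is an at least 10-fold higher number from compound 1 to compound 3 (1.00 log units; beyond the scatter), while the step from compound 2 to compound 3 is a step that the two limits leave unreadable from compound 2 to compound 3, as both sit at the limit of > 200000 nM in this assay, at which 2 of the 3 values shown sit.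

Compound 4 `CCCOc1nc2c(c(=O)n(C)c(=O)n2C)n1CCCC(=O)Nc1ccc(C(C)C)cc1` arises from compound 2 by ethyl in place of hydrogen on a saturated chain carbon bound to an oxygen on an aromatic ring, so the methoxy becomes a propoxy. Within the data shown here, no measured step touches this ether; the measured steps alter only the amide side and the alkyl on the ring, and they all start from the one compound with a number, compound 1. Compound 2 itself sits at a limit, so the step to compound 4 can only be bounded from one side. The lengthening is expected to leave compound 4 near where compound 2 stands, with an estimated step of an at least 1.3-fold lower number from compound 2 to compound 4 (0.12 log units; that floor lies within the scatter). Compound 4 is therefore expected at 150000 nM in this assay, within a range from 30000 nM to 400000 nM.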

Compound 4, half-maximal inhibitory concentration: 37600 nM
Compound 4: middle estimate off by 4.0-fold (0.60 log units), on the high side; the measured number falls inside the stated range.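

Up to this point the shared core carried the same methoxy in every compound shown, so the earlier steps said nothing about this position. In this assay, the change from methoxy to propoxy gives an at least 5.3-fold lower number from compound 2 to compound 4 (0.72 log units; beyond the scatter), which shows that the ether position can itself move the read-out. With the 4-isopropylphenyl amide held fixed, adding ethyl on the saturated chain carbon bound to the oxygen turns a limit into a measured number, but the step remains only a floor, and its true size cannot be read, because compound 2 has a limit and not a number: the limit of > 200000 nM in this assay, at which 2 of the 4 values shown sit.

As far as these compounds go, whether an ethoxy group, a butoxy group or a longer ether chain would give a lower or a higher number than the propoxy of compound 4 stays open, as does the effect of a free hydroxyl or an amine at this place. Also open, from the compounds shown here alone, is whether propoxy in place of methoxy would give a step of similar size on the 4-(tert-butyl)phenyl amide of compound 1 or the 2-chlorobenzyl amide of compound 3.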